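Azo-salicylate in place of the aniline amino group

This account rests on a few compounds, and the source may have more. Where it says the series, first, only, none or still open, it means among the compounds named here.

Measured so far:
compound 1 `Cc1nc2cnccc2n1CC1CCN(C(=O)CN(c2ccccc2)S(=O)(=O)c2ccc(N)cc2)CC1`: 75 nM
compound 2 `CCOC(=O)[C@H](CC(C)C)N(Cc1ccc(N)cc1)S(=O)(=O)c1ccc(Cn2c(C)nc3cnccc32)cc1`: 12 nM
compound 3 `Cc1nc2cnccc2n1CC1CCN(C(=O)CN(c2ccccc2)S(=O)(=O)c2ccc(/N=N\c3ccc(O)c(C(=O)O)c3)cc2)CC1`: 4010 nM

The read-out is a functional assay on the whole organism with Oryctolagus cuniculus as the target; on this read-out higher numbers stand for weaker inhibition and lower numbers for stronger inhibition. Compound 2 carries the lowest number of the three; its gap to compound 1 and its gap to compound 3 are both beyond the scatter. Compound 2 and compound 1 share the aminophenyl-sulfonamide motif on different cores; the difference between the two cores is not broken down here.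

Compound 3 differs from compound 1 by a group of 12 heavy atoms (7 carbon, 2 nitrogen, 3 oxygen; one six-membered aromatic ring of carbon only) in place of one nitrogen atom, on an aromatic carbon. This step, a 53-fold higher number from compound 1 to compound 3 (1.73 log units; beyond the scatter), is large.

Compound 4 `CCOC(=O)[C@H](CC(C)C)N(Cc1ccc(/N=N\c2ccc(O)c(C(=O)O)c2)cc1)S(=O)(=O)c1ccc(Cn2c(C)nc3cnccc32)cc1` is not yet measured. It differs from compound 2 by a group of 12 heavy atoms (7 carbon, 2 nitrogen, 3 oxygen; one six-membered aromatic ring of carbon only) in place of one nitrogen atom, on an aromatic carbon. The place line is the same as for compound 1 to compound 3, so this is the same change made on the other core.

For the measured compounds named here, only one measured instance of the change exists, on a different core, so the expected step from compound 2 to compound 4 is taken as of similar size, a 50-fold higher number from compound 2 to compound 4 (1.70 log units; beyond the scatter), because compound 1 to compound 3 gave a 53-fold higher number from compound 1 to compound 3 (1.73 log units; beyond the scatter). The estimate for compound 4 in this assay is 600 nM, with a range from 150 nM to 3000 nM.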

Compound 4, half-maximal inhibitory concentration: 490 nM
Beside the measured number, compound 4's estimate is 1.2-fold (0.09 log units) above it; measured number inside the range.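

In this assay, the azo-salicylate group in place of the amino group gives a 41-fold higher number from compound 2 to compound 4 (1.61 log units; beyond the scatter), so the large move towards weaker inhibition seen on the core of compound 1 recurs on the core of compound 2. The two steps agree in size: the same change on two cores in this assay, a 53-fold higher number (1.73 log units; beyond the scatter) from compound 1 to compound 3 and a 41-fold higher number (1.61 log units; beyond the scatter) from compound 2 to compound 4, 1.3-fold (0.12 log units) apart, within the scatter of two such steps. For the compounds shown here, this shows that, in this series, the change carried over from one core to the other with its size intact, but it rests on only two cores and does not show that a third core would behave alike, nor which features of the group account for the step.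

It remains open which part of the entering group goes with the loss, since a plain phenylazo group without the hydroxyl and the carboxylic acid does not appear among these compounds. A small acetamide on the same aromatic carbon would also show whether the step needs the whole azo-salicylate group or follows any replacement of the amino group.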